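The source may report more compounds than this note shows. Statements on the series, on what has been measured and on what is new or still open speak of the compounds shown alone.

Going by the values given here, in a functional assay on CHO.K1 cells for antagonist activity at prostaglandin D2 receptor 2 (Homo sapiens), read by GTPgammaS binding, with a stated time of 1 h (a lower number here means a stronger inhibitor, a higher number a weaker inhibitor), compound 2 `CCS(=O)(=O)c1ccccc1Cc1c2c(n(CC(=O)O)c1C)CCNC2=O` gives 550 nM, the higher of the two numbers known so far; compound 1 `COc1ccc(S(=O)(=O)c2ccccc2Cc2c3c(n(CC(=O)O)c2C)CCNC3=O)cc1` gives 3.9 nM, and the change a 140-fold higher number from compound 1 to compound 2 (2.15 log units; beyond the scatter) shows how much the group at this position matters. Compound 3 `Cc1c(Cc2ccccc2Cn2ccnn2)c2c(n1CC(=O)O)CCNC2=O` differs from compound 2 in that ((1H-1,2,3-triazol-1-yl)methyl in place of ethylsulfonyl on an aromatic carbon). Among the compounds with values here, no measured step replaces ethylsulfonyl with an aromatic ring here, so the only guide is that the larger aryl group in compound 1 was far better than ethyl; a partial recovery is therefore expected, with the step estimated as a 3.7-fold lower number from compound 2 to compound 3 (0.56 log units; beyond the scatter). Compound 3 is expected to give 150 nM, within 20 nM to 1500 nM.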

Compound 3, half-maximal inhibitory concentration: 800 nM
Compound 3: the middle estimate sits 5.3-fold (0.73 log units) below what was measured; low and high end bracket the measured number.
By their numbers in this assay, from the lowest: compound 1; then compounds 2 and 3 (each within the scatter of the next).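

In this assay, (1H-1,2,3-triazol-1-yl)methyl in place of ethylsulfonyl gives a 1.5-fold higher number from compound 2 to compound 3 (0.16 log units; within the scatter), so this aromatic carbon tolerates the loss of the sulfonyl group without a change beyond the scatter. A five-membered aromatic ring in the substituent does not restore the level of compound 1, as the comparison shows a 210-fold higher number from compound 1 to compound 3 (2.31 log units; beyond the scatter). No available evidence bears on this result. The compounds shown leave open whether the potency of compound 1 rests on its sulfonyl link, its phenyl ring or its methoxy group, which a plain phenylsulfonyl or a 4-methoxybenzyl group would separate.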